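The source may report more compounds than this note shows. Statements on the series, on what has been measured and on what is new or still open speak of the compounds shown alone.

Compound 1 `CS(=O)(=O)Nc1ccc2nccc(-c3ccncc3)c2n1`: 94%
Compound 2 `NS(=O)(=O)c1ccc(-c2ccc3nccc(-c4ccncc4)c3n2)cc1`: 36%
Compound 3 `O=S(=O)(NCc1ccccc1)c1cccc(Nc2ccc3nccc(-c4ccncc4)c3n2)c1`: 6%

These three compounds were tested in an ADME assay on microsomes from liver (Rattus norvegicus) for metabolic stability, read by LC-MS, using NADPH, with a stated time of 30 min, tested at 0.1 uM; a higher number here means that more of the compound is left, a lower number that less of the compound is left. Compound 1 gives 94%, the highest of the three numbers. Compound 2 and compound 3 both lie below it, by more than the usual scatter of repeated measurements.

Compound 4 `Nc1cccc(-c2ccc3nccc(-c4ccncc4)c3n2)c1` has not yet been measured. Compared with compound 1, it carries 3-aminophenyl in place of methanesulfonamido on an aromatic carbon.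

Going by the values given here, no two measured compounds differ in just one place, so no direct step can serve as a guide. The closest comparison is compound 2, which also has a six-membered aromatic ring of carbon only at this place and gives 36%. A large downward move beyond the scatter is therefore expected in this assay. The expected change is estimated as a number 64 percentage points lower from compound 1 to compound 4 (beyond the scatter). For compound 4 the estimated value is 30%, with an expected range from 8% to 60%.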

Compound 4, percent of the compound remaining: 61%
Beside the measured number, compound 4's estimate is 31 percentage points below it, and the stated range ends below it.
By their numbers in this assay, from the lowest: compound 3; then compound 2; then compound 4; then compound 1.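

Going by these compounds alone, this is the first direct step at this position: in this assay, 3-aminophenyl in place of methanesulfonamido on an aromatic carbon gives a number 33 percentage points lower from compound 1 to compound 4 (beyond the scatter). With the rest of the molecule unchanged, the group at this one place is enough to move the amount of compound left by more than the usual scatter. Nothing available explains why the number falls with this exchange.

From the compounds shown here alone, what stays open is whether the fall follows the phenyl ring itself or the amino group on it: a plain phenyl at this place would separate the two. Equally open, going by these compounds, is whether a small amine set directly on this aromatic carbon, with no ring in between, would leave the number nearer to that of compound 1.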